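Nitro in Place of Methoxy on the Core of Compound 1

This account rests on a few compounds, and the source may have more. Where it says the series, first, only, none or still open, it means among the compounds named here.

Compound 1 `CCCCCCCCCCCCCCNC(=O)[C@H](CO)NCc1ccccc1OC`: 100000 nM
Compound 2 `CCCCCCCCCCCCCCNC(=O)[C@H](CO)/N=C/c1ccc(OC)cc1`: 28100 nM
Compound 3 `CCCCCCCCCCCCCCNC(=O)[C@H](CO)/N=C/c1ccccc1`: 7670 nM

In a functional assay on cells (Homo sapiens) for cytotoxicity, read by MTT assay, with a stated time of 24 h (a lower number here means a stronger inhibitor, a higher number a weaker inhibitor), compound 1 gives the highest of the three numbers: a 3.6-fold lower number from compound 1 to compound 2 (0.55 log units; beyond the scatter) and a 13-fold lower number from compound 1 to compound 3 (1.12 log units; beyond the scatter). Compound 4 `CCCCCCCCCCCCCCNC(=O)[C@H](CO)NCc1ccccc1[N+](=O)[O-]` differs from compound 1 by nitro in place of methoxy on an aromatic carbon. For the measured compounds named here, no measured step exchanges one group on that aromatic carbon for another while the rest stays fixed; the nearest relative is a 3.7-fold lower number from compound 2 to compound 3 (0.56 log units; beyond the scatter), where methoxy is merely removed. That step and the two from compound 1 all point toward lower numbers when the methoxy is altered, so a modest step downward is expected, a 2.2-fold lower number from compound 1 to compound 4 (0.35 log units; beyond the scatter). Compound 4 is therefore estimated at 45000 nM, within 12000 nM to 150000 nM.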

Compound 4, half-maximal inhibitory concentration: 29400 nM
For compound 4 the middle estimate is 1.5-fold (0.18 log units) above the measured one, within the range that was stated.
By their numbers in this assay, from the lowest: compound 3; then compounds 2 and 4 (each within the scatter of the next); then compound 1.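

In this assay, for the compounds shown here, the exchange gives a 3.4-fold lower number from compound 1 to compound 4 (0.53 log units; beyond the scatter) and is the first measured step in which one group replaces another on this aromatic carbon, ortho to a large group, while the rest of compound 1 stays fixed. It shows that the number depends on the group held at this place, and that the change from 2-methoxybenzyl to 2-nitrobenzyl lowers it beyond the scatter. No measurement shown here accounts for this step.

On these data alone, whether an amine or a carboxylic acid on the same carbon would lower the number further remains open. So does how plain hydrogen at this place would compare with nitro and methoxy on the core of compound 1.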